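Taking the 4-methoxyphenyl away from a sigma-1 ligand

This account rests on a few compounds, and the source may have more. Where it says the series, first, only, none or still open, it means among the compounds named here.

Compound 2 `COc1ccc(-c2csc3c2CC(OC)OC32CCN(Cc3ccccc3)CC2)cc1` and compound 1 `COC1Cc2cc(-c3ccccc3)sc2C2(CCN(Cc3ccccc3)CC2)O1` share one core and differ only in the ring attached to its five-membered aromatic ring with one sulfur. For the measured compounds named here, in an assay on membranes from brain for displacement of a labelled ligand from Sigma non-opioid intracellular receptor 1 (Cavia porcellus), read by scintillation counting, with a stated time of 120 min (a lower number here means a stronger inhibitor, a higher number a weaker inhibitor), compound 2 gives 7.1 nM, the lower of the two numbers known, while compound 1 gives 16 nM; that gap lies beyond the usual scatter. Compound 3 `COC1Cc2ccsc2C2(CCN(Cc3ccccc3)CC2)O1` carries no such ring at all: hydrogen in place of 4-methoxyphenyl on an aromatic carbon. Going by the values given here, no measured pair isolates this change, so its size must be judged from what is known. Since compound 1, carrying phenyl at that place, gives 16 nM while compound 2 gives 7.1 nM, the attached ring appears to move the number, and losing it is expected to weaken binding by a step of a 5.6-fold higher number from compound 2 to compound 3 (0.75 log units; beyond the scatter). Compound 3 is therefore estimated at 40 nM in this assay, most likely between 10 nM and 200 nM.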

Compound 3, inhibition constant: 1.9 nM
For compound 3 the middle estimate is 21-fold (1.32 log units) above the measured one, outside the stated range (below it).
By their numbers in this assay, from the lowest: compound 3; then compound 2; then compound 1.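

Removing the ring altogether strengthens binding in this assay: hydrogen in place of 4-methoxyphenyl gives a 3.7-fold lower number from compound 2 to compound 3 (0.57 log units; beyond the scatter), and hydrogen in place of phenyl gives an 8.4-fold lower number from compound 1 to compound 3 (0.93 log units; beyond the scatter). The two ring-bearing compounds alone could only compare one ring with another, whereas these steps show that binding at this receptor does not depend on a ring at this aromatic carbon, and that compound 3, with only hydrogen there, is the strongest of the three. Nothing available explains why either ring gives a weaker result than hydrogen.

From the compounds shown here alone, whether a methyl group or a chlorine atom on this carbon would keep the number close to that of compound 3, or move it towards those of the ring-bearing compounds, remains open. Also open, going by these compounds, is whether this order holds at any other receptor.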